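Bromo to chloro on the benzylidene arm of compound 2

This account rests on a few compounds, and the source may have more. Where it says the series, first, only, none or still open, it means among the compounds named here.

The series shares one core with two benzylidene arms and an allyl group. Compound 1 `C=CCn1c(=O)/c(=C\c2ccc(F)c(Br)c2)[nH]c(=O)/c1=C\c1ccccc1OC` gives "not active" (no number reported) in a functional assay on K562 cells (Homo sapiens) for cytotoxicity, read by CCK-8 assay, with a stated time of 72 h; on this read-out lower numbers stand for stronger inhibition and higher numbers for weaker inhibition. Compound 3 `C=CCn1c(=O)/c(=C\c2cccc(Br)c2)[nH]c(=O)/c1=C\c1cccc(Br)c1` gives "not active" (no number reported) in this assay. Going by the values given here, compound 2 `C=CCn1c(=O)/c(=C\c2cccc(Br)c2)[nH]c(=O)/c1=C\c1ccccc1OC` gives 2400 nM in this assay; it is the only compound of the three with a reported number, the other two entries standing without one, so it is the sole anchor for any estimate.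

Compound 4 `C=CCn1c(=O)/c(=C\c2cccc(Cl)c2)[nH]c(=O)/c1=C\c1ccccc1OC` is not yet measured. It differs from compound 2 by chloro in place of bromo on an aromatic carbon, which cut one bond further out reads 3-bromophenyl to 3-chlorophenyl. Among the compounds with values here, no measured pair in the set shows this change, so its effect here is unknown. A swap of one halogen for another of the same kind is usually a small step, and nothing in the data points in either direction, so the expectation is a step of no more than the scatter, with some chance that compound 4 falls outside the measurable window as compound 1 and compound 3 did. Compound 4 is expected to give about 3000 nM in this assay, within 1200 nM to 8000 nM, which means an estimated step of a 1.3-fold higher number from compound 2 to compound 4 (0.10 log units; within the scatter).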

Compound 4, half-maximal inhibitory concentration: 2700 nM
Beside the measured number, compound 4's estimate is 1.1-fold (0.05 log units) above it; the measured number falls inside the stated range.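

In this assay, the exchange of 3-bromophenyl for 3-chlorophenyl gives a 1.1-fold higher number from compound 2 to compound 4 (0.05 log units; within the scatter), so on this aromatic carbon, meta to a large group, the two halogens cannot be told apart. Going by these compounds alone, the earlier compounds could not show this, as compound 2 was the only one with a number; the series now has a second compound with a measurable value, and that value does not depend on bromo at this place. No accompanying measurement bears on this result, so the data offer no explanation for it.

The compounds shown leave open how far this tolerance extends, as they cover only two halogens here and say nothing about an amine, a nitrile or a carboxylic acid on the same carbon. Also open, as far as these compounds go, is whether the chloro arm would lose its measurable value under the same changes that separate compound 1 and compound 3 from compound 2, and whether a longer chain in place of the allyl group would alter the reading in this assay.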